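Swapping an Ester Link for a Benzyl Group

This account rests on a few compounds, and the source may have more. Where it says the series, first, only, none or still open, it means among the compounds named here.

In a functional assay on HT-29 cells (Homo sapiens) for inhibition, read by MTT assay, with a stated time of 72 h (on this read-out lower numbers stand for stronger inhibition and higher numbers for weaker inhibition), compound 1 (`CC(C)=CCC/C(C)=C/C[C@@H]1C[C@]2(CC=C(C)C)C(=O)[C@@](CC=C(C)C)(C(=O)C(C(=O)c3ccc(O)c(OC(=O)CCCC[C@@H]4SCC5NC(=O)NC54)c3)=C2O)[C@@]1(C)CCC=C(C)C`) gives 18200 nM and compound 2 (`CC(C)=CCC/C(C)=C/C[C@@H]1C[C@]2(CC=C(C)C)C(=O)[C@@](CC=C(C)C)(C(=O)C(OC(=O)c3ccc(O)c(O)c3)=C2O)[C@@]1(C)CCC=C(C)C`) gives 16300 nM on the same test. These two numbers lie within the usual scatter of repeated measurements, so compound 2 cannot be told apart from compound 1 here, and the two values are all there is to go on.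

Compound 3 (`CC(C)=CCC/C(C)=C/C[C@@H]1C[C@]2(CC=C(C)C)C(=O)[C@@](CC=C(C)C)(C(=O)C(Cc3ccc(O)c(O)c3)=C2O)[C@@]1(C)CCC=C(C)C`) keeps the shared core of compound 2 and changes one place: 3,4-dihydroxybenzyl in place of ((3,4-dihydroxyphenyl)carbonyl)oxy on a double-bonded ring carbon with 3,4-dihydroxybenzyl in place of ((3,4-dihydroxyphenyl)carbonyl)oxy on a double-bonded ring carbon. For the measured compounds named here, no measured pair shows what this swap does, so no shift beyond the scatter, in either direction, is expected in this assay for now. The expected step of a 1.1-fold lower number from compound 2 to compound 3 (0.04 log units; within the scatter) is accordingly small. For compound 3 the estimated value is 15000 nM with an expected range from 6000 nM to 35000 nM on this read-out.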

Compound 3, half-maximal inhibitory concentration: > 20000 nM
Compound 3: no number, only a limit; the forecaster's own chance of this, stated with the estimate: 10%; at least 1.3-fold (0.12 log units) between middle value and limit.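

In this assay compound 3 gives no number, only a limit: > 20000 nM. For the compounds shown here, putting 3,4-dihydroxybenzyl in place of ((3,4-dihydroxyphenyl)carbonyl)oxy on this double-bonded ring carbon gives the first reading of this change, an at least 1.2-fold higher number from compound 2 to compound 3 (0.08 log units; that floor lies within the scatter), so the swap shows no loss of inhibition beyond the scatter, yet a larger loss is not ruled out. The step can only be stated as a floor because the result for compound 3 is capped: the limit of > 20000 nM in this assay, at which 1 of the 3 values shown sits.

Going by these compounds, how far the true value of compound 3 lies past its limit remains open. So does whether an amine, a carboxylic acid or a longer chain on this same ring carbon would give a clearly lower or higher number than the groups shown here.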